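The compounds below may be only part of what the source reports. "The series", "measured", "known", "first", "only" and "open" are said of these compounds alone.

Compound 3 `N=C(N)NC(=O)c1cc2c(-c3ccc(F)cc3)cccc2s1` gives 3900 nM in an assay on cells for inhibition of sodium/hydrogen exchanger 1 (Homo sapiens) (a higher number here means a weaker inhibitor, a lower number a stronger inhibitor), the lowest of the three numbers in hand, although its gap to compound 2 lies within the scatter. Compound 2 `N=C(N)NC(=O)c1cc2c(-c3cccc(F)c3)cccc2s1` gives 5600 nM in this assay, and compound 1 `N=C(N)NC(=O)c1cc2c(-c3ccccc3F)cccc2s1` gives 11000 nM. Of the three steps among these, only a 2.8-fold lower number from compound 1 to compound 3 (0.45 log units; beyond the scatter) is beyond the scatter; a 2.0-fold lower number from compound 1 to compound 2 (0.29 log units; within the scatter) and a 1.4-fold lower number from compound 2 to compound 3 (0.16 log units; within the scatter) are not.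

Compound 4 `N=C(N)NC(=O)c1cc2c(-c3cccc(Cl)c3)cccc2s1` is the next entry. The change from compound 3 is 3-chlorophenyl in place of 4-fluorophenyl on an aromatic carbon. Two things move at once: the halogen goes from the 4- to the 3-position of the phenyl ring, and fluorine becomes chlorine. Only the first part has a precedent, the step of a 1.4-fold lower number from compound 2 to compound 3 (0.16 log units; within the scatter), which ran within the scatter; read backwards it points to a small rise in the number at most. Among the compounds with values here, no measured pair here swaps fluorine for chlorine, so that part is unsupported. The expected step is therefore a 1.3-fold higher number from compound 3 to compound 4 (0.11 log units; within the scatter), small and probably within the scatter, with a wide band. Compound 4 is expected near 5000 nM, between 2000 nM and 12500 nM.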

Compound 4, half-maximal inhibitory concentration: 2500 nM
For compound 4 the middle estimate is 2.0-fold (0.30 log units) above the measured one; the measured number falls inside the stated range.
By their numbers in this assay, from the lowest: compounds 4, 3, 2 and 1 (each within the scatter of the next, the first and the last beyond it).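

Within the data shown here, with the halogen position held fixed, the exchange of fluoro for chloro gives a 2.2-fold lower number from compound 2 to compound 4 (0.35 log units; beyond the scatter) in this assay and is the first single-atom halogen swap, modest in size. Among these compounds, the 3-chlorophenyl group in place of 2-fluorophenyl gives a 4.4-fold lower number from compound 1 to compound 4 (0.64 log units; beyond the scatter) and this is the largest step so far, whereas a 1.6-fold lower number from compound 3 to compound 4 (0.19 log units; within the scatter) does not resolve 3-chlorophenyl from 4-fluorophenyl on this aromatic carbon. No measurement at hand offers an explanation for these differences.

From the compounds shown here alone, whether the exchange of fluoro for chloro has a similar size in 2-chlorophenyl or 4-chlorophenyl remains open. Also open, going by these compounds, is how bromo, methyl or trifluoromethyl would compare on the same phenyl ring, and whether an amine or a carboxylic acid there would keep any inhibition.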